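A few compounds are considered here, and "the series" means these few. Any claim that something is new, unique, unknown or untested is made for them only; others in the source may bear on it.

Compound 1 `CC(Nc1ccccc1Oc1ccc(Cl)cc1)=C1C(=O)CC(c2ccccc2)CC1=O` gives 190 nM
Compound 2 `COc1ccc(Oc2ccccc2NC(C)=C2C(=O)CC(c3ccccc3)CC2=O)cc1OC` gives 160 nM
Compound 3 `CC(Nc1ccccc1Oc1ccccc1)=C1C(=O)CC(c2ccccc2)CC1=O` gives 170 nM

In a functional assay on CCRF-CEM cells (Homo sapiens) for antiproliferative activity, read by cell counting, with a stated time of 96 h (on this read-out lower numbers stand for stronger inhibition and higher numbers for weaker inhibition), compound 3 stands within the scatter of both compound 1 and compound 2, so the three values show no order. Compound 4 `CC(Nc1ccccc1Oc1ccc(C(C)O)cc1)=C1C(=O)CC(c2ccccc2)CC1=O` carries 1-hydroxyethyl in place of hydrogen on an aromatic carbon, para to a large group (1-hydroxyethyl in place of hydrogen on an aromatic carbon). The nearest measured changes are a 1.1-fold lower number from compound 1 to compound 3 (0.05 log units; within the scatter) and a 1.1-fold higher number from compound 2 to compound 3 (0.03 log units; within the scatter), and both are small. Neither of them tests a 1-hydroxyethyl group, so the expectation remains uncertain. No step beyond the scatter is expected, and the estimated change is a 1.2-fold higher number from compound 3 to compound 4 (0.07 log units; within the scatter). For compound 4 the estimated value is 200 nM, expected to fall between 90 nM and 450 nM.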

Compound 4, half-maximal inhibitory concentration: 120 nM
Estimate against measurement, compound 4: 1.7-fold (0.22 log units) above, and the stated range covers the measured number.
By their numbers in this assay, from the lowest: compounds 4, 2, 3 and 1 (each within the scatter of the next).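

Placing 1-hydroxyethyl on this aromatic carbon, para to a large group, gives in this assay a 1.4-fold lower number from compound 3 to compound 4 (0.15 log units; within the scatter) against hydrogen, a 1.6-fold lower number from compound 1 to compound 4 (0.20 log units; within the scatter) against chloro and a 1.3-fold lower number from compound 2 to compound 4 (0.12 log units; within the scatter) with 4-(1-hydroxyethyl)phenyl in place of 3,4-dimethoxyphenyl. For the compounds shown here, the position thus takes a group with a hydrogen-bond donor, which no earlier compound carried there, without any step beyond the scatter. Nothing shown here offers an explanation for this. On these data alone, whether an amine, a carboxylic acid or a longer chain on this carbon would move the number beyond the scatter stays open.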